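Notes on the series: bromo for tert-butyl, cytotoxicity

A few compounds are considered here, and "the series" means these few. Any claim that something is new, unique, unknown or untested is made for them only; others in the source may bear on it.

Compound 1 `CC(C)(C)c1ccc(C(=O)/C=C/c2ccc([N+](=O)[O-])o2)cc1` in an ADME assay on THP-1 cells (Homo sapiens) for cytotoxicity, read by resazurin assay, with a stated time of 72 h (a higher number here means that more compound is tolerated, a lower number that less compound is tolerated), gives only a limit, > 50000 nM. Compound 2 `O=C(/C=C/c1ccc([N+](=O)[O-])s1)c1ccc(C2CCCCC2)cc1` likewise reaches only the limit of > 50000 nM. Compound 3 `CSc1ccc(C(=O)/C=C/c2ccc([N+](=O)[O-])s2)cc1` gives a number, 8560 nM. Within the data shown here, the one measured step, an at least 5.8-fold lower number from compound 2 to compound 3 (0.76 log units; beyond the scatter), shows that exchanging the group on an aromatic carbon lowered the tolerated concentration, though the limit of > 50000 nM in this assay, at which 2 of the 3 values shown sit, leaves its full size open. Compound 4 `O=C(/C=C/c1ccc([N+](=O)[O-])o1)c1ccc(Br)cc1` carries the change (bromo in place of tert-butyl on an aromatic carbon). Among the measured compounds shown here, no measured step covers bromo itself; the step from compound 2 to compound 3 is the nearest comparison and points down. For compound 4 a modest fall is therefore expected, an at least 1.6-fold lower number from compound 1 to compound 4 (0.22 log units; that floor lies within the scatter), with a fair chance that only the limit is again reported. Compound 4 is estimated at 30000 nM, between 9000 nM and 60000 nM.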

Compound 4, half-maximal cytotoxic concentration: 13400 nM
Beside the measured number, compound 4's estimate is 2.2-fold (0.35 log units) above it; the measured number falls inside the stated range.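

Bromo in place of tert-butyl, on an aromatic carbon para to a large group, brings in this assay an at least 3.7-fold lower number from compound 1 to compound 4 (0.57 log units; beyond the scatter). A change at this place therefore also moves the number on the core of compound 1, whereas the earlier step rested on the core of compound 2 alone. The step stays a floor because compound 1 gives only a limit: the limit of > 50000 nM in this assay, at which 2 of the 4 values shown sit.

On these data alone, what an amine or a carboxylic acid would give at this place remains open. So does whether bromo gives a similar fall on the core of compound 2.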